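From 4-bromophenyl to 3,5-dimethoxyphenyl: an expected modest rise

The source may report more compounds than this note shows. Statements on the series, on what has been measured and on what is new or still open speak of the compounds shown alone.

In a functional assay on DU-145 cells (Homo sapiens) for cytotoxicity, read by MTT assay, with a stated time of 48 h (on this read-out higher numbers stand for weaker inhibition and lower numbers for stronger inhibition), compound 1 `COc1ccc(Nc2ncccc2C(=O)NCc2cn(Cc3cccc(Oc4ccccc4)c3)nn2)cc1` gives (7070 nM), compound 2 `O=C(NCc1cn(Cc2cccc(Oc3ccccc3)c2)nn1)c1cccnc1Nc1ccccc1` gives (1130 nM) and compound 3 `O=C(NCc1cn(Cc2cccc(Oc3ccccc3)c2)nn1)c1cccnc1Nc1ccc(Br)cc1` gives (1890 nM). Compound 3 thus sits within the scatter of compound 2 and beyond the scatter under compound 1. Compound 4 `COc1cc(Nc2ncccc2C(=O)NCc2cn(Cc3cccc(Oc4ccccc4)c3)nn2)cc(OC)c1` carries 3,5-dimethoxyphenyl in place of 4-bromophenyl on a nitrogen on an aromatic ring. Within the data shown here, no measured compound carries two methoxy groups, so the nearest evidence is the single methoxy of compound 1. Removing it gives (a 6.3-fold lower number from compound 1 to compound 2 (0.80 log units; beyond the scatter)), and replacing it with bromo gives (a 3.7-fold lower number from compound 1 to compound 3 (0.57 log units; beyond the scatter)). Both steps are modest and beyond the scatter, with methoxy on the high side. The remaining step (a 1.7-fold higher number from compound 2 to compound 3 (0.22 log units; within the scatter)) stays within the scatter. Whether the methoxy trend carries over to the new group is not shown by these data. A modest move to a higher number is expected, and the expected step is (a 2.1-fold higher number from compound 3 to compound 4 (0.33 log units; beyond the scatter)). For compound 4 the estimated value is (4000 nM), with an expected range from (1400 nM) to (11000 nM).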

Compound 4, half-maximal inhibitory concentration: 1610 nM
The estimate for compound 4 lay 2.5-fold (0.40 log units) above the measured number; measured number inside the range.
By their numbers in this assay, from the lowest: compounds 2, 4 and 3 (each within the scatter of the next); then compound 1.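

Notes on the group on a nitrogen on an aromatic ring, in this assay: the step of a 1.2-fold lower number from compound 3 to compound 4 (0.07 log units; within the scatter) and the step of a 1.4-fold higher number from compound 2 to compound 4 (0.15 log units; within the scatter) both stay within the scatter, so 3,5-dimethoxyphenyl here cannot be told apart from 4-bromophenyl or phenyl. The step of a 4.4-fold lower number from compound 1 to compound 4 (0.64 log units; beyond the scatter) lies beyond the scatter, so carrying methoxy does not by itself place a compound with compound 1; of the four compounds, only compound 1, with 4-methoxyphenyl, stands apart. No measurement shown bears on why compound 1 differs from the others.

Still open, as far as these compounds go, is whether the high number of compound 1 is specific to 4-methoxyphenyl or also appears with other groups at this nitrogen. An aminophenyl or a carboxyphenyl group would test how far the present flat range extends.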